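The source may report more compounds than this note shows. Statements on the series, on what has been measured and on what is new or still open speak of the compounds shown alone.

Measured compounds:
- compound 1, `N#Cc1cnc(NC(=O)CCCOc2ccccc2)s1`, 0.25 h
- compound 2, `CC(C)c1cnc(NC(=O)CCCOc2ccccc2)s1`, 0.0333 h
- compound 3, `O=C(CCCOc1ccccc1)Nc1ncc(Cl)s1`, 0.0333 h

All three were run in an ADME assay on microsomes from liver (Mus musculus) for metabolic stability, read by LC-MS, using NADPH, tested at 1 uM; a lower number here means that the compound disappears faster, a higher number that the compound lasts longer. Compound 1 holds the highest of the three numbers; the move to the isopropyl analogue is a 7.5-fold lower number from compound 1 to compound 2 (0.88 log units; beyond the scatter), and the move to the chloro analogue is a 7.5-fold lower number from compound 1 to compound 3 (0.88 log units; beyond the scatter). Between compound 2 and compound 3 there is no change at the digits printed from compound 2 to compound 3 (within the scatter).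

Compound 4, `N#Cc1cnc(NC(=O)CCCOc2cccc(Cl)c2)s1`, is not yet measured. Against compound 1 the change is chloro in place of hydrogen on an aromatic carbon. The measured steps all concern the group on the shared core, not the phenyl ring, so none of them bears directly on this change. Nothing in the present data points to a step beyond the scatter in either direction, and a number close to that of compound 1 is expected, with a wide range to allow for an unseen effect.

Compound 4 is thus estimated at 0.25 h, range 0.08 h to 0.6 h, which means an expected step of no change at the digits printed from compound 1 to compound 4 (within the scatter).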

Compound 4, half-life: 0.133 h
For compound 4 the middle estimate is 1.9-fold (0.27 log units) above the measured one, and the stated range covers the measured number.
By their numbers in this assay, from the lowest: compounds 2 and 3 (each within the scatter of the next); then compounds 4 and 1 (each within the scatter of the next).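

Going by these compounds alone, this is the first reading at the phenyl ring rather than at the group on the shared core: in this assay, chloro in place of hydrogen, meta to a large group on the six-membered aromatic ring, gives a 1.9-fold lower number from compound 1 to compound 4 (0.27 log units; within the scatter). With the nitrile kept on the core, this position therefore accepts a chloro without a step beyond the scatter, whereas replacing the nitrile itself gives a 7.5-fold lower number from compound 1 to compound 2 (0.88 log units; beyond the scatter) and a 7.5-fold lower number from compound 1 to compound 3 (0.88 log units; beyond the scatter). No evidence at hand bears on this result.

As far as these compounds go, whether the phenyl ring stays as undemanding with a methoxy group, an amine or a carboxylic acid at this position, or with chloro elsewhere on the ring, remains open. Also open, from the compounds shown here alone, is whether 3-chlorophenyl in place of phenyl reads the same with isopropyl or chloro on the core.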